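Methyl on the phenoxy ring of compound 2

This account rests on a few compounds, and the source may have more. Where it says the series, first, only, none or still open, it means among the compounds named here.

Measured compounds:
- compound 1 `Cc1cccc(N(C)C(=O)c2ccc(Oc3ccccc3C)cc2)c1`: "not active" (no number reported)
- compound 2 `Cc1cccc(N(C)C(=O)c2ccc(Oc3ccccc3)cc2)c1`: "not active" (no number reported)
- compound 3 `COc1cccc(N(C)C(=O)c2ccc(-c3ccc(C)c(C)c3)cc2)c1`: 13300 nM

In an assay for inhibition of 17-beta-hydroxysteroid dehydrogenase type 1 (Homo sapiens), read by HPLC, with a stated time of 10 min (on this read-out higher numbers stand for weaker inhibition and lower numbers for stronger inhibition), compound 2 gives "not active" (no number reported), with no number attached. Compound 1 likewise gives "not active" (no number reported) in this assay, so the two diaryl ether amides stand together without a single number between them. The only numeric anchor in the series is compound 3, which carries a biaryl in place of the diaryl ether and a methoxy on the anilide ring; in this assay compound 3 gives 13300 nM, a weak figure. Whether the ether compounds sit near that figure or far beyond it cannot be read from these entries.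

Compound 4 `Cc1ccc(Oc2ccc(C(=O)N(C)c3cccc(C)c3)cc2)cc1` is the next member. It differs from compound 2 by methyl in place of hydrogen on an aromatic carbon, in words: methyl in place of hydrogen on an aromatic carbon. For the measured compounds named here, no step between measured compounds shows what a methyl added to this ring does, and compound 1, which also carries a methyl on the phenoxy ring, remained without a number. The expectation is therefore no measurable gain: compound 4 is expected to remain weak or without a reportable number in this assay.

Compound 4 is estimated at 40000 nM, within a range of 10000 nM to 200000 nM.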

Compound 4, half-maximal inhibitory concentration: 26300 nM
Beside the measured number, compound 4's estimate is 1.5-fold (0.18 log units) above it; the range from low to high includes it.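

No step can be read from compound 2 to compound 4: in this assay compound 2 gives "not active" (no number reported) and compound 4 at 26300 nM has no number to be set against it. The compounds shown leave open how large a change phenoxy to 4-methylphenoxy brings to inhibition. No measurement offered here bears on the result.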